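The compounds below may be only part of what the source reports. "The series", "measured", "known", "first", "only" and "open" are said of these compounds alone.

Of the compounds shown here, three with a shared core have been tested in a functional assay on cells (Cancer cell lines, Homo sapiens) for inhibition, with a stated time of 48 h; a higher number here means a weaker inhibitor of growth, a lower number a stronger inhibitor of growth. Compound 1, whose structure is `COc1cc2c(/C=C3/C(=O)N(C)c4ccccc43)c(Cl)n(C)c2cc1C`, gives 10000 nM in this assay. Compound 2, with the structure `COc1cc2c(/C=C3/C(=O)N(C)c4ccc(O)cc43)c(Cl)n(C)c2cc1C`, differs from compound 1 by a single change: hydroxy in place of hydrogen on an aromatic carbon. That change made a step of a 3.2-fold lower number from compound 1 to compound 2 (0.50 log units; beyond the scatter), so in this assay compound 2 gives 3160 nM.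

Compound 3, drawn as `COc1cc2c(/C=C3/C(=O)N(C)c4ccccc43)c[nH]c2cc1C`, carries a different core; how its core differs from that of compound 1 is not broken down here. In this assay compound 3 gives 81300 nM, the highest of the three numbers measured, with compound 1 nearest to it and compound 2 furthest from it.

Compound 4, with the structure `COc1cc2c(/C=C3/C(=O)N(C)c4ccc(O)cc43)c[nH]c2cc1C`, has not yet been measured. It stands to compound 3 as compound 2 stands to compound 1: the change is hydroxy in place of hydrogen on an aromatic carbon, the same change made at the same kind of place as before. If the hydroxy group carries over the same effect on the core of compound 3, then in this assay a step of about a 2.9-fold lower number from compound 3 to compound 4 (0.46 log units; beyond the scatter) is expected from compound 3 to compound 4, resting on the measured step of a 3.2-fold lower number from compound 1 to compound 2 (0.50 log units; beyond the scatter). Compound 4 is therefore estimated to give 28000 nM in this assay, with a range from 10000 nM to 80000 nM allowing for the chance that the hydroxy group acts differently on the second core.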

Compound 4, concentration for total growth inhibition: 15900 nM
Estimate against measurement, compound 4: 1.8-fold (0.25 log units) above, within the range that was stated.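

In this assay, hydroxy in place of hydrogen on an aromatic carbon again lowers the number on the second core, giving a step of a 5.1-fold lower number from compound 3 to compound 4 (0.71 log units; beyond the scatter). Set beside each other, the two steps agree in direction, and the gap between their sizes is no larger than repeated measurements would be expected to produce: the same change on two cores in this assay, a 3.2-fold lower number (0.50 log units; beyond the scatter) from compound 1 to compound 2 and a 5.1-fold lower number (0.71 log units; beyond the scatter) from compound 3 to compound 4, 1.6-fold (0.21 log units) apart, within the scatter of two such steps This shows that the hydroxy change carried from one core to the other in these two pairs, but the larger second step cannot be read as a stronger effect on that core, and two pairs say nothing about any further core or about why the change lowers the number.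

The compounds shown leave open whether a different group on the same aromatic carbon, such as methoxy, an amine or a carboxylic acid, would lower the number as hydroxy does. They also leave open whether hydroxy would have a similar effect on another aromatic carbon of the same ring.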